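The source may report more compounds than this note shows. Statements on the series, on what has been measured and on what is new or still open speak of the compounds shown alone.

Measured compounds: compound 1 `CNc1nc(C)c(C(=O)N/N=C/c2ccccc2C(F)(F)F)s1`, > 100 ug/mL; compound 2 `CN(C(=O)NC(=O)c1ccccc1F)c1nc(C(F)(F)F)c(C(=O)N/N=C/c2ccccc2C(F)(F)F)s1`, 10.1 ug/mL; compound 3 `CN(C(=O)NC(=O)c1c(F)cccc1F)c1nc(C(F)(F)F)c(C(=O)N/N=C/c2ccccc2C(F)(F)F)s1`, 19.6 ug/mL.

In a functional assay on HeLa cells (Homo sapiens) for inhibition, read by MTT assay, with a stated time of 72 h (on this read-out lower numbers stand for stronger inhibition and higher numbers for weaker inhibition), compound 2 gives the lowest of the two numbers shown. The step of a 1.9-fold higher number from compound 2 to compound 3 (0.29 log units; within the scatter) lies within the scatter, so compound 2 and compound 3 cannot be told apart. The value of compound 1 is a limit of the assay, not a number (the limit of > 100 ug/mL in this assay, at which 1 of the 3 values shown sits). Compound 4 `CNc1nc(C(F)(F)F)c(C(=O)N/N=C/c2ccccc2C(F)(F)F)s1` arises from compound 2 by hydrogen in place of ((2-fluorophenyl)carbonyl)carbamoyl on a nitrogen on an aromatic ring. For the measured compounds named here, no measured step matches this change directly. Compound 1 carries the same hydrogen on that nitrogen, and its value is a limit. Compound 4 is therefore expected to give a clearly higher number, the step of a 7.9-fold higher number from compound 2 to compound 4 (0.90 log units; beyond the scatter), an estimate of 80 ug/mL, ranging from 30 ug/mL to 200 ug/mL, with a fair chance that only a limit is reported.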

Compound 4, half-maximal inhibitory concentration: > 100 ug/mL
Compound 4: no number, only a limit; the forecaster's own chance of this, stated with the estimate: 60%; middle value at least 1.2-fold (0.09 log units) away from the limit.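

Replacing ((2-fluorophenyl)carbonyl)carbamoyl with hydrogen on the nitrogen gives an at least 9.9-fold higher number from compound 2 to compound 4 (0.99 log units; beyond the scatter) in this assay, so this group matters for inhibition in compound 2, a link that compound 1, which differs from compound 2 in two places, could not show. Compound 4 gives only a limit, not a number: the limit of > 100 ug/mL in this assay, at which 2 of the 4 values shown sit. Compound 1 and compound 4 are both limits, so the effect of trifluoromethyl in place of methyl cannot be read. Open, as far as these compounds go, is whether a smaller group on that nitrogen, such as acetyl, would retain any inhibition.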